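Swapping Benzyl for Butoxy: What to Expect Next

The source may hold more compounds than are shown below. What is called first, only, known or untested is meant among the compounds shown, and "the series" means these compounds.

Of the compounds shown here, three have been measured in a functional assay on NCI-H522 cells (Homo sapiens) for inhibition, read by sulforhodamine B assay, with a stated time of 48 h; on this read-out higher numbers stand for weaker inhibition of growth and lower numbers for stronger inhibition of growth. Compound 1 `O=C(Nc1ccccc1OC(F)(F)F)Nc1n[nH]c2ccccc12` gives 33900 nM. Compound 2 `Nc1nn(C(=O)Nc2ccc(Cc3ccccc3)cc2)c2ccccc12` gives 2900 nM, the lower of the two numbers, and its gap to compound 1 lies beyond the usual scatter. Compound 3 `COc1ccc(NC(=O)Nc2n[nH]c3ccccc23)cc1` reaches only the assay limit of > 100000 nM, which is not a number. Compound 4 `CCCCOc1ccc(NC(=O)n2nc(N)c3ccccc32)cc1` keeps the core of compound 2 and changes a single group: butoxy in place of benzyl on an aromatic carbon. Within the data shown here, no two measured compounds differ in only one place, so no measured step guides this change, and compound 3 rests on a different core than compound 4. A small step toward weaker inhibition is expected, a 1.7-fold higher number from compound 2 to compound 4 (0.24 log units; within the scatter). Compound 4 is therefore estimated at 5000 nM, between 1500 nM and 20000 nM.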

Compound 4, concentration for 50% growth inhibition: 27400 nM
Compound 4: middle estimate off by 5.5-fold (0.74 log units), on the low side; measured number outside the range, above it.
By their numbers in this assay, from the lowest: compound 2; then compounds 4 and 1 (each within the scatter of the next). At a limit, above all of these: compound 3.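

In this assay, this position, para to a large group, responds clearly to the change: butoxy in place of benzyl gives a 9.4-fold higher number from compound 2 to compound 4 (0.98 log units; beyond the scatter). The swap removes a six-membered aromatic ring and adds a hydrogen-bond acceptor, and this single step cannot separate those two differences. Compound 4 still gives a number rather than a limit, so the step can be read in full: the limit of > 100000 nM in this assay, at which 1 of the 4 values shown sits.

Going by these compounds, it remains open whether a phenoxy group, which carries both an oxygen and a ring, would read closer to compound 2 or to compound 4.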